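A few compounds are considered here, and "the series" means these few. Any claim that something is new, unique, unknown or untested is made for them only; others in the source may bear on it.

Compound 1 `CCn1ncnc1-c1ccccc1NCC1=NCCN1` has the lowest number of the two measured compounds in an in vitro functional assay on cells (Fibroblast) for agonist activity at Alpha-1A adrenergic receptor (Homo sapiens) (a higher number here means that more compound is needed for the effect, a lower number that less compound is needed), where compound 1 gives 1.26 nM. Compound 2 `Cc1ccc(-c2ccccc2NCC2=NCCN2)n1C` gives 50.1 nM in this assay, a gap beyond the usual scatter. Compound 3 `Cn1ncnc1-c1ccccc1NCC1=NCCN1` has not yet been measured. It differs from compound 1 by hydrogen in place of methyl on a saturated chain carbon bound to an aromatic nitrogen. No measured pair among these compounds shows a step of this kind, so its size is unknown. The step is expected to be small, a 1.6-fold higher number from compound 1 to compound 3 (0.20 log units; within the scatter), toward a slightly higher number. Compound 3 is accordingly estimated at 2 nM, with a range from 0.6 nM to 6.3 nM.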

Compound 3, half-maximal effective concentration: 2 nM
Beside the measured number, compound 3's estimate shows no gap at the digits printed; low and high end bracket the measured number.
By their numbers in this assay, from the lowest: compounds 1 and 3 (each within the scatter of the next); then compound 2.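

Going from ethyl to methyl, with hydrogen in place of methyl on a saturated chain carbon bound to an aromatic nitrogen, gives a 1.6-fold higher number from compound 1 to compound 3 (0.20 log units; within the scatter) in this assay. At this position, therefore, the ethyl and methyl groups cannot be told apart in this assay. Among these compounds, this is the only step read at this place, so it holds for this pair alone, and nothing measured here bears on the result. As far as these compounds go, whether a longer chain, such as propyl or butyl, or a chain ending in an amine would give a number close to those of compound 1 and compound 3 remains open.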